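The source may report more compounds than this note shows. Statements on the series, on what has been measured and on what is new or still open speak of the compounds shown alone.

In a functional assay on P388 cells (Mus musculus) for antiproliferative activity, read by colorimetric assay and MTT assay (on this read-out higher numbers stand for weaker inhibition and lower numbers for stronger inhibition), compound 1 `Nc1ccc(S(=O)(=O)Nc2cccc3c(Cl)c[nH]c23)cc1` gives 0.81 ug/mL, compound 2 `Nc1ccc(S(=O)(=O)Nc2ccc(F)c3c(Cl)c[nH]c23)cc1` gives 0.51 ug/mL and compound 3 `Cc1ccc(NS(=O)(=O)c2ccc(N)cc2)c2[nH]cc(Cl)c12` gives 0.37 ug/mL. Compound 3 shares the low end of these numbers with compound 2 and is clearly separated only from compound 1. The two comparisons are a 1.4-fold lower number from compound 2 to compound 3 (0.14 log units; within the scatter) and a 2.2-fold lower number from compound 1 to compound 3 (0.34 log units; beyond the scatter).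

Next is compound 4 `Nc1ccc(S(=O)(=O)Nc2ccc(-c3ccccc3)c3c(Cl)c[nH]c23)cc1`, with phenyl in place of methyl on an aromatic carbon. The measured steps at this same carbon are the only guide: a 1.6-fold lower number from compound 1 to compound 2 (0.20 log units; within the scatter), and the methyl step already given above. Both are small, and the replacement of fluoro by methyl also stayed within the scatter. For the measured compounds named here, no measured compound carries a ring at this carbon, so the guide is weak and the range must stay wide. In this assay, no step beyond the scatter is expected, with a slight lean towards a higher number. Expected step: a 1.4-fold higher number from compound 3 to compound 4 (0.13 log units; within the scatter). For compound 4 the estimated value is 0.5 ug/mL, with an expected range of 0.17 ug/mL to 1.5 ug/mL.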

Compound 4, half-maximal inhibitory concentration: 19 ug/mL
Compound 4: the middle estimate sits 38-fold (1.58 log units) below what was measured; measured number above the stated range.
By their numbers in this assay, from the lowest: compounds 3, 2 and 1 (each within the scatter of the next, the first and the last beyond it); then compound 4.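

In this assay the hydrogen, fluoro and methyl compounds differ by modest steps at most, but phenyl at this same carbon gives a much larger change: a 51-fold higher number from compound 3 to compound 4 (1.71 log units; beyond the scatter) and a 37-fold higher number from compound 2 to compound 4 (1.57 log units; beyond the scatter) and a 23-fold higher number from compound 1 to compound 4 (1.37 log units; beyond the scatter). For the compounds shown here, what is tolerated at this carbon among the smaller substituents therefore does not carry over to phenyl, and the earlier steps gave no sign of a change of this size. Nothing at hand bears on why phenyl departs so far from the other three.

Open, as far as these compounds go, is where between methyl and phenyl the numbers begin to rise: ethyl, methoxy or cyclohexyl at this carbon would separate a larger saturated or chain substituent from an aromatic ring. Also open, from the compounds shown here alone, is whether a pyridyl ring, or a phenyl carrying an amine, would behave as phenyl does.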